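Fluoro to chloro on the shared core, growth inhibition

The source may hold more compounds than are shown below. What is called first, only, known or untested is meant among the compounds shown, and "the series" means these compounds.

Measured in a functional assay on HCT-116 cells (Homo sapiens) for inhibition, read by sulforhodamine B assay, with a stated time of 48 h, tested at 50 uM; a higher number here means more inhibition of growth at the concentration tested, a lower number less inhibition of growth:
compound 1 `O=C1C(=O)N(CCCCn2cc(COc3cc(=O)oc4ccccc34)nn2)c2ccc(F)cc21` gives 67%
compound 2 `O=C1C(=O)N(CCCn2cc(COc3cc(=O)oc4ccccc34)nn2)c2ccc(F)cc21` gives 75%
compound 3 `O=C1C(=O)N(CCCCCn2cc(COc3cc(=O)oc4ccccc34)nn2)c2ccc([N+](=O)[O-])cc21` gives 29%

Compound 2 holds the highest number of the three in this assay; compound 1 lies within the scatter of it, so no order between those two can be read, while compound 3 sits beyond the scatter below it. Compound 4 `O=C1C(=O)N(CCCn2cc(COc3cc(=O)oc4ccccc34)nn2)c2ccc(Cl)cc21` is not yet measured. It differs from compound 2 by chloro in place of fluoro on an aromatic carbon. Among the compounds with values here, no step between measured compounds of this kind is available, so its size in this assay cannot be taken from the data; no step beyond the scatter is expected in either direction. For compound 4 the estimated value is 72%, with a range from 55% to 88%. The estimated step of a number 3 percentage points lower from compound 2 to compound 4 (within the scatter) is expected to stay within the scatter.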

Compound 4, percent growth inhibition at one concentration: 68%
The estimate for compound 4 lay 4 percentage points above the measured number; low and high end bracket the measured number.
By their numbers in this assay, from the lowest: compound 3; then compounds 1, 4 and 2 (each within the scatter of the next).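

In this assay, within the data shown here, chloro in place of fluoro on an aromatic carbon of the shared core gives a number 7 percentage points lower from compound 2 to compound 4 (within the scatter) and is the only step that isolates this position. With the rest of the structure unchanged, the two halogens cannot be ordered at this position, and this single pair shows that the change is tolerated here. No measurement on hand offers an explanation for this result. Going by these compounds, whether bromo, methoxy or an amine on this same aromatic carbon would also stay within the scatter of compound 2 remains open.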